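A few compounds are considered here, and "the series" means these few. Any claim that something is new, unique, unknown or untested is made for them only; others in the source may bear on it.

For the measured compounds named here, compound 2 `CCCCNc1nc(N)nc2c1CN(C(=O)c1cnccn1)CC2` stands at the higher of the two numbers measured so far in an assay on HEK293 cells for agonist activity at Toll-like receptor 8 (Homo sapiens), read by a luciferase reporter, with a stated time of 6 h; a lower number here means that less compound is needed, a higher number that more compound is needed for the effect: compound 2 gives 2.2 uM, while compound 1 `CCCCNc1nc(N)nc2c1CN(Cc1ccccn1)CC2` gives 0.07 uM. Going by the values given here, the single measured step, a 31-fold higher number from compound 1 to compound 2 (1.50 log units; beyond the scatter), exchanged the linking group and the ring at the same time, so it does not separate what the ring contributed from what the carbonyl contributed. Compound 3 `CCCCNc1nc(N)nc2c1CN(C(=O)c1cscn1)CC2` keeps the carbonyl of compound 2 and changes only the ring: 1,3-thiazol-4-yl in place of pyrazin-2-yl on a carbonyl carbon. Among the compounds with values here, no measured step isolates such a ring exchange on a carbonyl carbon, so the data give no direction for it, and a change within the usual scatter is expected. Compound 3 is therefore expected to sit close to compound 2, with an estimated step of a 1.5-fold lower number from compound 2 to compound 3 (0.17 log units; within the scatter). For compound 3 the estimate in this assay is 1.5 uM, ranging from 0.4 uM to 6 uM.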

Compound 3, minimum effective concentration: 0.5 uM
Compound 3: the middle estimate sits 3.0-fold (0.48 log units) above what was measured; low and high end bracket the measured number.
By their numbers in this assay, from the lowest: compound 1; then compound 3; then compound 2.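

In this assay, the ring on the carbonyl carbon proves to matter in its own right: with the carbonyl held fixed, 1,3-thiazol-4-yl in place of pyrazin-2-yl gives a 4.4-fold lower number from compound 2 to compound 3 (0.64 log units; beyond the scatter) and so moves the number beyond the scatter, an effect that the earlier step could not separate from the change of linking group. The (1,3-thiazol-4-yl)carbonyl group still falls short of (pyridin-2-yl)methyl, with a 7.1-fold higher number from compound 1 to compound 3 (0.85 log units; beyond the scatter) as the remaining gap, so the ring exchange recovers only part of a 31-fold higher number from compound 1 to compound 2 (1.50 log units; beyond the scatter) and nothing available accounts for the effect of the exchange.

As far as these compounds go, it remains open how much of that gap belongs to the carbonyl and how much to the ring, a question that a (1,3-thiazol-4-yl)methyl group on the same nitrogen would address. A single exchange also does not show whether the gain follows the five-membered ring or its sulfur.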